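Replacing a cyano group with methyl: expected cytotoxicity

A few compounds are considered here, and "the series" means these few. Any claim that something is new, unique, unknown or untested is made for them only; others in the source may bear on it.

Compound 1 `Cc1cc(C#N)cc(C)c1Oc1ccnc(NCCn2ccc(=O)[nH]c2=O)n1`: 35800 nM
Compound 2 `Cc1cc(C)cc(Oc2nc(NCCn3ccc(=O)[nH]c3=O)ncc2Cl)c1`: > 322000 nM
Compound 3 `Cc1cc(/C=C/C#N)cc(C)c1Oc1nc(NCCn2ccc(=O)[nH]c2=O)ncc1Cl`: > 284000 nM

For the measured compounds named here, in an ADME assay on MT4 cells (Homo sapiens) for cytotoxicity, read by MTT assay, with a stated time of 5 days (a lower number here means that less compound is tolerated, a higher number that more compound is tolerated), compound 1 gives 35800 nM, the only exact number of the three. Compound 2 shows > 322000 nM, which is a limit. Compound 3 shows > 284000 nM, also a limit.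

Compound 4 `Cc1cc(C)c(Oc2ccnc(NCCn3ccc(=O)[nH]c3=O)n2)c(C)c1` differs from compound 1 by methyl in place of cyano on an aromatic carbon, with methyl in place of cyano on an aromatic carbon. Going by the values given here, no measured pair isolates this change. Compound 2 carries no cyano group and stands at > 322000 nM, a limit that favours a modest rise, though compound 3 keeps a nitrile and goes against this reading. The expected change in this assay is a 2.4-fold higher number from compound 1 to compound 4 (0.38 log units; beyond the scatter), upward and just beyond the scatter. Compound 4 is estimated at 85000 nM, with an expected range of 20000 nM to 340000 nM.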

Compound 4, half-maximal cytotoxic concentration: 272000 nM
For compound 4 the middle estimate is 3.2-fold (0.51 log units) below the measured one, and the stated range covers the measured number.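

In this assay, for the compounds shown here, methyl in place of cyano on this aromatic carbon, para to a large group, gives a 7.6-fold higher number from compound 1 to compound 4 (0.88 log units; beyond the scatter), the first pair in which this single change can be read. Compound 4 carries an exact number, so the step is a measured one and not bounded by a limit. Nothing measured here bears on why the number rises.

Going by these compounds, whether the rise comes from gaining methyl or from losing cyano stays open. An amine, a methoxy group or plain hydrogen on the same carbon would help to separate the two.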